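The source may report more compounds than this note shows. Statements on the series, on what has been measured and on what is new or still open speak of the compounds shown alone.

In a functional assay on SMMC-7721 cells (Homo sapiens) for cytotoxicity, read by MTT assay, with a stated time of 4 days (a higher number here means a weaker inhibitor, a lower number a stronger inhibitor), the measured compounds stand as follows. Compound 1 `Cc1ccc(-c2cn(C[C@H]3c4c(ccc(OS(=O)(=O)c5ccc(C)cc5)c4C)[C@@H]4CC[C@@]5(C)C[C@]43CC5=O)nn2)cc1` gives > 20000 nM, which is a limit of the assay. Compound 2 `C=C1C[C@]23C[C@@]1(O)CC[C@@H]2c1cccc(C)c1[C@@H]3Cn1cc(-c2ccc(C(F)(F)F)cc2)nn1` gives > 20000 nM, also a limit. Compound 3 `Cc1ccc(S(=O)(=O)Oc2ccc3c(c2C)[C@H](Cn2cc(-c4ccc(C(F)(F)F)cc4)nn2)[C@@]24CC(=O)[C@@](C)(CC[C@@H]32)C4)cc1` gives > 20000 nM, again a limit.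

The change from compound 3 to compound 1 is methyl in place of trifluoromethyl on an aromatic carbon, and its step in this assay is a step that the two limits leave unreadable from compound 3 to compound 1, since (the limit of > 20000 nM in this assay, at which 3 of the 3 values shown sit). How the core of compound 2 differs from that of compound 3 is not broken down here.

Compound 4 `C=C1C[C@]23C[C@@]1(O)CC[C@@H]2c1cccc(C)c1[C@@H]3Cn1cc(-c2ccc(C)cc2)nn1` differs from compound 2 by methyl in place of trifluoromethyl on an aromatic carbon, the same change. Compound 4 is therefore expected to give 20000 nM in this assay, between 6000 nM and 60000 nM. This estimate, a step of a number no higher from compound 2 to compound 4 (the limit leaves the size open), rests on the limit shown by compound 2, > 20000 nM, and on the unreadable step that the two limits leave unreadable from compound 3 to compound 1.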

Compound 4, half-maximal inhibitory concentration: > 20000 nM
Compound 4: a limit, no number (the forecaster's own chance of this, stated with the estimate: 75%); the middle value lies on the limit itself.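

No step can be read from compound 2 to compound 4, as both values are limits of the assay: the limit of > 20000 nM in this assay, at which 4 of the 4 values shown sit.

The compounds shown leave open whether methyl in place of trifluoromethyl on an aromatic carbon shifts potency at all in this assay.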